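Ring enlargement on the amide: compound 3 to compound 4

The source may report more compounds than this note shows. Statements on the series, on what has been measured and on what is new or still open speak of the compounds shown alone.

The series shares one core, seen in compound 1 `O=C(Nc1nc(-c2cccc(F)c2)cs1)c1ccc([N+](=O)[O-])o1` and compound 2 `CC(=O)Nc1cccc(-c2csc(NC(=O)c3ccc([N+](=O)[O-])o3)n2)c1`, which were both measured in an ADME assay on Vero cells (Chlorocebus sabaeus) for cytotoxicity, read by MTT assay, with a stated time of 72 h; a lower number here means a stronger inhibitor, a higher number a weaker inhibitor. In this assay compound 1 gives 51600 nM, and compound 2 gives 57600 nM. The step of a 1.1-fold higher number from compound 1 to compound 2 (0.05 log units; within the scatter) shows that exchanging the aryl substituent left the read-out essentially where it was. Compound 3 `O=C(Nc1nc(-c2cccc(NC(=O)C3CCCC3)c2)cs1)c1ccc([N+](=O)[O-])o1` carries a (cyclopentylcarbonyl)amino group at that same position, but in this assay compound 3 gives "not determined" (no result reported), so it has no standing on the numbers at hand. Compound 4 `O=C(Nc1nc(-c2cccc(NC(=O)C3CCCCC3)c2)cs1)c1ccc([N+](=O)[O-])o1` differs from compound 3 by cyclohexyl in place of cyclopentyl on a carbonyl carbon. Among the compounds with values here, no measured step touches this carbonyl substituent, and the one step that exists, from fluoro to acetamido, was within the scatter; nothing here suggests that adding one carbon to the ring should move the read-out beyond the scatter. Compound 4 is therefore expected to give about 55000 nM in this assay, with a range from 20000 nM to 150000 nM.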

Compound 4, half-maximal inhibitory concentration: 21900 nM
For compound 4 the middle estimate is 2.5-fold (0.40 log units) above the measured one, within the range that was stated.
By their numbers in this assay, from the lowest: compound 4; then compounds 1 and 2 (each within the scatter of the next).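

Compound 3 has no number in this assay, and the step from it to compound 4 cannot be read. Compound 4 nevertheless gives the first movement beyond the scatter in this series: a 2.6-fold lower number from compound 2 to compound 4 (0.42 log units; beyond the scatter) with cyclohexyl in place of methyl on a carbonyl carbon, and a 2.4-fold lower number from compound 1 to compound 4 (0.37 log units; beyond the scatter) with (cyclohexylcarbonyl)amino in place of fluoro on an aromatic carbon, both modest, whereas the earlier exchange of fluoro for acetamido had stayed within the scatter. The data offer no measured explanation for this shift.

From the compounds shown here alone, whether the cyclohexyl ring specifically matters, or whether cyclopentyl would read the same, remains open while compound 3 has no number. Also open, going by these compounds, is how a phenyl group, a longer carbon chain or an amine on that carbonyl carbon would read.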